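Carboxylic acid in place of tetrazole on the shared core

A few compounds are considered here, and "the series" means these few. Any claim that something is new, unique, unknown or untested is made for them only; others in the source may bear on it.

Compound 1 `c1ccc2nc(COc3ccc(OCCCc4nnn[nH]4)cc3)ccc2c1` gives 69 nM in an assay on membranes from lung (Cavia porcellus) for binding affinity to cysteinyl leukotriene receptor (Homo sapiens) (on this read-out higher numbers stand for weaker inhibition and lower numbers for stronger inhibition), the highest of the three numbers in hand. Compound 2 `c1cc(OCCCc2nnn[nH]2)cc(OCc2ccc3ccccc3n2)c1` gives 42 nM, which lies within the scatter of compound 1, while compound 3 `c1ccc(C(CCc2nnn[nH]2)Cc2cccc(OCc3ccc4ccccc4n3)c2)cc1` gives 14 nM, beyond the scatter below compound 1. No two of these compounds differ in a single place, so no step size can be read directly from them. Compound 4 `O=C(O)CCCCc1ccc(OCc2ccc3ccccc3n2)cc1` differs from compound 1 by 4-carboxybutyl in place of 3-(1H-tetrazol-5-yl)propoxy on an aromatic carbon. With nothing measured on this exchange, the step from compound 1 to compound 4 is expected to be a 2.2-fold higher number from compound 1 to compound 4 (0.34 log units; beyond the scatter), a modest move toward weaker binding near the edge of the scatter. Compound 4 is therefore estimated at 150 nM, with a range from 40 nM to 600 nM.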

Compound 4, inhibition constant: 110 nM
Estimate against measurement, compound 4: 1.4-fold (0.13 log units) above; the range from low to high includes it.
By their numbers in this assay, from the lowest: compound 3; then compounds 2, 1 and 4 (each within the scatter of the next, the first and the last beyond it).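

In this assay, the first step read at this position, on an aromatic carbon para to a large group, is a 1.6-fold higher number from compound 1 to compound 4 (0.20 log units; within the scatter). On the shared core, the five-membered aromatic ring with 4 hetero atoms can therefore give way to an open chain ending in a carboxylic acid without a change that can be read. No measured property bears on this result.

The exchange alters the end group and the linking atom together, and a 3-carboxypropoxy chain on the same carbon would separate the two. Going by these compounds, whether the exchange behaves alike on the cores of compound 2 and compound 3 stays open.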